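The compounds below may be only part of what the source reports. "The series", "measured", "known", "first", "only" and "open" are said of these compounds alone.

Of the compounds shown here, three have been tested so far in an assay on isolated protein for displacement of a labelled ligand from metabotropic glutamate receptor 5 (Homo sapiens); a lower number here means a stronger inhibitor, a higher number a weaker inhibitor. Compound 1, `CN1CC(=O)N/C1=N\C(=O)Nc1ccccc1Cl`, gives 2520 nM, the highest of the three numbers and therefore the weakest binding among them. The other two are built on a different core: compound 2, `Cc1cccc(C#Cc2cccc(Cl)c2)n1`, gives 3 nM, and compound 3, `Cc1cccc(C#Cc2ccncc2)n1`, gives 26 nM. Against these, compound 1 is far behind: its nearest neighbour is compound 3, whose number is well beyond the scatter below it, and compound 2 lies further still.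

The next compound, compound 4, `CN1CC(=O)N/C1=N\C(=O)Nc1ccccc1`, is compound 1 with a single change: hydrogen in place of chloro on an aromatic carbon. The chloro that sat on an aromatic carbon of the six-membered carbon ring, ortho to a large group, is gone, and a hydrogen stands there instead.

Within the data shown here, no pair of measured compounds differs in exactly this way, so nothing measured shows what the removal of the chloro does in this assay. Stripping a substituent from an already weak binder more often costs a little than gains, so the step from compound 1 to compound 4 is expected to be a small loss, a 2.0-fold higher number from compound 1 to compound 4 (0.30 log units; within the scatter), though one that may not clear the scatter. On that basis compound 4 is estimated at 5000 nM, with a likely range from 1500 nM to 20000 nM.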

Compound 4, half-maximal inhibitory concentration: 1360 nM
Estimate against measurement, compound 4: 3.7-fold (0.57 log units) above; the measured number lies below the stated range.
By their numbers in this assay, from the lowest: compound 2; then compound 3; then compounds 4 and 1 (each within the scatter of the next).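

In this assay, replacing the chloro on the aromatic carbon with hydrogen gives a 1.9-fold lower number from compound 1 to compound 4 (0.27 log units; within the scatter), so compound 1 and compound 4 cannot be told apart in this assay. Among these compounds, this is the first direct look at this position: the chloro, a single heavy atom ortho to a large group, can be removed without a change that rises above the ordinary variation between repeat measurements, and the weak binding of compound 1 therefore does not depend measurably on it. No separate measurement is available to explain this result.

Still open, on these data alone, is whether a different group on the same aromatic carbon, such as a methoxy group or an amine, would shift the number beyond the scatter, and whether a chloro elsewhere on that six-membered ring would behave as it does here. Also open is whether the same swap would matter as little on the different core of compound 2, which carries a chloro of its own, as its hydrogen counterpart is not among the compounds shown.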